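Moving the bromine around the phenoxy ring of compound 2

The compounds below may be only part of what the source reports. "The series", "measured", "known", "first", "only" and "open" are said of these compounds alone.

Measured compounds:
compound 1 `NC1=NC2(CCOCC2)N(OCCCOc2ccc(Cl)c(Cl)c2)C(N)=N1`: 90 nM
compound 2 `NC1=NC2(CCSCC2)N(OCCCOc2ccc(Br)cc2)C(N)=N1`: 20 nM
compound 3 `CC(C)(C)c1ccc(OCCCON2C(N)=NC(N)=NC23CCSCC3)cc1`: 1 nM

Of the compounds shown here, three have been tested in a functional assay on HCT-116 cells (Homo sapiens) for antiproliferative activity, read by MTT assay, with a stated time of 72 h; a lower number here means a stronger inhibitor, a higher number a weaker inhibitor. Compound 2 stands second highest of the three numbers, with 20 nM. Its nearest neighbour is compound 1, which gives 90 nM, a higher number beyond the scatter; the furthest is compound 3, which gives 1 nM. For the measured compounds named here, the only single-point step among the measured compounds is a 20-fold lower number from compound 2 to compound 3 (1.30 log units; beyond the scatter).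

Compound 4 `NC1=NC2(CCSCC2)N(OCCCOc2ccccc2Br)C(N)=N1` has not yet been measured. It differs from compound 2 as follows: 2-bromophenyl in place of 4-bromophenyl on an oxygen on a saturated carbon. The measured step from compound 2 to compound 3 concerns a different change, the exchange of one substituent for another on the aromatic carbon, and does not speak to a shift of the same bromine to another position on the ring. Going by the values given here, no measured pair therefore bears on this step. With nothing to indicate a direction, compound 4 is expected to fall close to compound 2 in this assay, with a step of a 2.0-fold higher number from compound 2 to compound 4 (0.30 log units; within the scatter) that may or may not exceed the scatter. The estimate for compound 4 is 40 nM, within a range from 10 nM to 160 nM.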

Compound 4, half-maximal inhibitory concentration: 1 nM
Estimate against measurement, compound 4: 40-fold (1.60 log units) above; measured number outside the range, below it.
By their numbers in this assay, from the lowest: compounds 3 and 4 (each within the scatter of the next); then compound 2; then compound 1.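

In this assay, the change from 4-bromophenoxy to 2-bromophenoxy gives a 20-fold lower number from compound 2 to compound 4 (1.30 log units; beyond the scatter), so the place of the bromine on the ring matters in its own right. The earlier step, a 20-fold lower number from compound 2 to compound 3 (1.30 log units; beyond the scatter), showed only that exchanging the substituent at one ring position could move the number, whereas here the two compounds have the same atoms, joined differently. Both single changes measured on the phenoxy ring of compound 2 therefore lower the number by a large step, and neither change raises it, although two changes are too few to establish a wider pattern. Nothing measured here bears on the reason for this result.

Going by these compounds, it remains open whether a chlorine, a methoxy group or a nitrile in place of the bromine of compound 4 would keep the number as low, or whether the effect belongs to bromine alone. Also open, on these data alone, is whether the same shift of the bromine would have a similar effect with a longer chain on the oxygen, or on the core of compound 1.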